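This account rests on a few compounds, and the source may have more. Where it says the series, first, only, none or still open, it means among the compounds named here.

Measured compounds:
- compound 1 `COc1ccccc1/C=c1/[nH]c(=O)/c(=C\c2ccccc2OC)n(C)c1=O` — in a functional assay on U-937 cells (Homo sapiens) for cytotoxicity, read by CCK-8 assay, with a stated time of 72 h (on this read-out lower numbers stand for stronger inhibition and higher numbers for weaker inhibition), compound 1 gives 1500 nM
- compound 2 `C=CCn1c(=O)/c(=C\c2ccccc2Cl)[nH]c(=O)/c1=C\c1ccccc1OC` — in this assay compound 2 gives 700 nM

Of the two numbers available, compound 2 holds the lower one. Its nearest neighbour is compound 1, whose number is higher by a margin that lies beyond the usual scatter of this assay, so compound 2 stands as the lower of the pair on this read-out.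

Compound 3 `C=CCn1c(=O)/c(=C\c2cccc(Br)c2)[nH]c(=O)/c1=C\c1ccccc1OC` has not yet been measured. It differs from compound 2 in one place: 3-bromophenyl in place of 2-chlorophenyl on a double-bonded chain carbon bound to an aromatic carbon. For the measured compounds named here, no step between measured compounds matches this exchange, so there is nothing in the data to say how large an effect it carries or in which direction.

With that in mind, the expected step for the change a 1.1-fold higher number from compound 2 to compound 3 (0.06 log units; within the scatter) is none beyond the scatter of this assay. Compound 3 is therefore estimated at 800 nM, with a range from 300 nM to 2500 nM to allow for the absence of any matching precedent.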

Compound 3, half-maximal inhibitory concentration: 1100 nM
Estimate against measurement, compound 3: 1.4-fold (0.14 log units) below; the measured number falls inside the stated range.
By their numbers in this assay, from the lowest: compounds 2, 3 and 1 (each within the scatter of the next, the first and the last beyond it).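

In this assay, for the compounds shown here, putting 3-bromophenyl in place of 2-chlorophenyl on a double-bonded chain carbon bound to an aromatic carbon gives a 1.6-fold higher number from compound 2 to compound 3 (0.20 log units; within the scatter) and so provides the first reading of a change made in this one place. The step lies within the usual scatter, so on this read-out the two halogen-bearing phenyl groups cannot be told apart, something the earlier pair, compound 1 and compound 2, could not show as they differ in more than one place. No measurement bearing on this result is available to account for it.

Because the halogen and its place on the phenyl ring differ together in this single step, the contribution of each remains unresolved, and 2-bromophenyl or 3-chlorophenyl on the same chain carbon would be needed to separate them. On these data alone, it also remains open whether the tolerance seen here extends beyond halogen-bearing phenyl groups, for example to a phenyl group carrying an amine or a carboxylic acid.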